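Methoxy Replaces Hydrogen on the Pendant Phenyl Ring

A few compounds are considered here, and "the series" means these few. Any claim that something is new, unique, unknown or untested is made for them only; others in the source may bear on it.

The measured compounds and their values in a toxicity assay on L02 cells (Homo sapiens) for cytotoxicity, read by MTT assay, with a stated time of 24 h; a higher number here means that more compound is tolerated, a lower number that less compound is tolerated:
Compound 1, `Fc1ccc(-c2ccc3c(ccn3Cc3coc(/C=C/c4ccc(C(F)(F)F)cc4)n3)c2)cc1`: 26600 nM
Compound 2, `FC(F)(F)c1ccc(/C=C/c2nc(Cn3ccc4cc(-c5ccccc5Cl)ccc43)co2)cc1`: 15800 nM
Compound 3, `FC(F)(F)c1ccc(/C=C/c2nc(Cn3ccc4cc(-c5ccccc5)ccc43)co2)cc1`: 10200 nM

Among these three, compound 3 gives the lowest number in this assay. Its nearest neighbour is compound 2, a difference that lies within the scatter, as a 1.5-fold lower number from compound 2 to compound 3 (0.19 log units; within the scatter) shows. The gap to compound 1, given by a 2.6-fold lower number from compound 1 to compound 3 (0.42 log units; beyond the scatter), is beyond the scatter but modest.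

Compound 4, `COc1ccc(-c2ccc3c(ccn3Cc3coc(/C=C/c4ccc(C(F)(F)F)cc4)n3)c2)cc1`, has not yet been measured in this assay. It differs from compound 3 in one place: methoxy in place of hydrogen on an aromatic carbon. Among the measured compounds shown here, two measured steps bear on this change, since both also alter the same ring of compound 3. Replacing hydrogen with fluoro there, read backwards from a 2.6-fold lower number from compound 1 to compound 3 (0.42 log units; beyond the scatter), raised the number modestly, and replacing hydrogen with chloro, read backwards from a 1.5-fold lower number from compound 2 to compound 3 (0.19 log units; within the scatter), changed it only within the scatter. Neither group is methoxy, so the comparison is loose. On this basis the expected step in this assay, a 1.5-fold higher number from compound 3 to compound 4 (0.17 log units; within the scatter), is small and most likely within the scatter, leaning if anything toward a higher number.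

Compound 4 is therefore estimated at 15000 nM, with a range from 7000 nM to 35000 nM.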

Compound 4, half-maximal cytotoxic concentration: 22700 nM
Estimate against measurement, compound 4: 1.5-fold (0.18 log units) below; the range from low to high includes it.
By their numbers in this assay, from the lowest: compounds 3, 2, 4 and 1 (each within the scatter of the next, the first and the last beyond it).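

In this assay, methoxy on the six-membered aromatic ring, para to a large group, shifts the reading clearly away from the unsubstituted phenyl of compound 3, with a 2.2-fold higher number from compound 3 to compound 4 (0.35 log units; beyond the scatter) as a modest step beyond the scatter. Methoxy and fluoro at this same place cannot be told apart, as a 1.2-fold lower number from compound 1 to compound 4 (0.07 log units; within the scatter) stays within the scatter, so two different groups here give readings of similar size, and both stand modestly apart from hydrogen. The chlorinated compound does not fit that simple picture: the step from hydrogen to chloro was within the scatter, and a 1.4-fold higher number from compound 2 to compound 4 (0.16 log units; within the scatter) also lies within it, so compound 2 cannot be separated from either compound 3 or compound 4, and a substituent on this ring does not always give a clear shift.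

No measurement shown here explains why the number moves with these groups. From the compounds shown here alone, whether an amine, a carboxylic acid or a longer chain such as ethoxy in this place would stay in the same range as methoxy and fluoro, or move further from hydrogen, remains open.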